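A few compounds are considered here, and "the series" means these few. Any claim that something is new, unique, unknown or untested is made for them only; others in the source may bear on it.

Measured in a functional assay on A549 cells (Homo sapiens) for cytotoxicity, read by MTT assay, with a stated time of 48 h; a lower number here means a stronger inhibitor, a higher number a weaker inhibitor:
- compound 1 `COc1c(OCCCCN2CCNCC2)cc(O)c2c(=O)cc(-c3ccccc3)oc12`: 1740 nM
- compound 2 `COc1c(OCc2nc3ccccc3[nH]2)cc(O)c2c(=O)cc(-c3ccccc3)oc12`: > 100000 nM (a limit of the assay)
- compound 3 `COc1c(OCCCCNCc2ccccc2)cc(O)c2c(=O)cc(-c3ccccc3)oc12`: 4590 nM

Of the two actual numbers in this assay, compound 3 holds the higher, 4590 nM. The step that reaches it from its nearest neighbour is modest: a 2.6-fold higher number from compound 1 to compound 3 (0.42 log units; beyond the scatter). Compound 2 has only a limit, not a number.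

Compound 4 `COc1c(OCc2ncc(C)o2)cc(O)c2c(=O)cc(-c3ccccc3)oc12` carries 5-methyl-1,3-oxazol-2-yl in place of 3-(benzylamino)propyl on a saturated chain carbon bound to an oxygen on an aromatic ring.

Going by the values given here, the closest precedent is the large exchange at the same place in compound 2, an at least 21-fold lower number from compound 2 to compound 3 (1.33 log units; beyond the scatter). The other large step, an at least 57-fold higher number from compound 1 to compound 2 (1.75 log units; beyond the scatter), points the same way. Compound 4 also has a ring in that place, although a smaller one than compound 2, so a large move to a higher number is expected, perhaps somewhat less extreme. The expected step is an 8.7-fold higher number from compound 3 to compound 4 (0.94 log units; beyond the scatter). For compound 4 the estimated value is 40000 nM, with an estimated range from 8000 nM to 100000 nM.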

Compound 4, half-maximal inhibitory concentration: > 100000 nM
Compound 4: only a limit was reported; the forecaster's own chance of this, stated with the estimate: 50%; middle value at least 2.5-fold (0.39 log units) away from the limit.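

In this assay, compound 4 gives only a limit of the assay, > 100000 nM, not a number. Placing 5-methyl-1,3-oxazol-2-yl on the saturated chain carbon bound to an oxygen on an aromatic ring gives an at least 21-fold higher number from compound 3 to compound 4 (1.33 log units; beyond the scatter) and an at least 57-fold higher number from compound 1 to compound 4 (1.75 log units; beyond the scatter), so the loss seen earlier is not peculiar to 1H-benzimidazol-2-yl. Compound 2 and compound 4 now sit at the same limit, so the step between them cannot be read: the limit of > 100000 nM in this assay, at which 2 of the 4 values shown sit.

The compounds shown do not tell whether the amine or the chain of compound 1 and compound 3 matters more, as the two ring groups differ from them in both. A 5-methyl-1,3-oxazol-2-yl at the end of a longer chain, or a plain alkyl chain without an amine, would separate the two.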